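The source may report more compounds than this note shows. Statements on the series, on what has been measured and on what is new or still open speak of the compounds shown alone.

Measured compounds:
- compound 1, `COC(=O)c1ccc(CN2CCC(O)(Cn3cnc4c(cnn4-c4ccc(F)cc4)c3=O)CC2)c(F)c1`: 800 nM
- compound 2, `O=c1c2cnn(-c3ccc(F)cc3)c2ncn1CC1(O)CCN(Cc2ccc(Cl)cc2C(F)(F)F)CC1`: "not determined" (no result reported)

In an assay on Sf21 cells for inhibition of ubiquitin carboxyl-terminal hydrolase 7 (Homo sapiens), read by spectrophotometry, with stated times of 30 min and 2 h (on this read-out lower numbers stand for stronger inhibition and higher numbers for weaker inhibition), compound 1 gives 800 nM. Compound 2 has no number in this assay; it stands nowhere on the scale, and nothing can be said of how it compares with compound 1. Compound 3, `N#Cc1cc(Cl)ccc1CN1CCC(O)(Cn2cnc3c(cnn3-c3ccc(F)cc3)c2=O)CC1`, differs from compound 2 only at the benzyl group on the piperidine nitrogen: cyano in place of trifluoromethyl on an aromatic carbon, in words cyano in place of trifluoromethyl on an aromatic carbon. Compound 3 is still to be tested in this assay. Among the compounds with values here, no step between two measured compounds is available, so the size of this change cannot be read from data; the expectation is no shift beyond the usual scatter, in either direction. Within the data shown here, the only anchor is the value of compound 1 in this assay, which carries a different benzyl substitution. Compound 3 is expected to give about 600 nM in this assay. The estimated range for compound 3 runs from 150 nM to 2500 nM.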

Compound 3, half-maximal inhibitory concentration: 11400 nM
Beside the measured number, compound 3's estimate is 19-fold (1.28 log units) below it; the measured number lies above the stated range.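

In this assay the substitution on the benzyl group at the piperidine nitrogen proves able to move the number on the shared core: a 14-fold higher number from compound 1 to compound 3 (1.15 log units; beyond the scatter), so 4-chloro-2-cyanophenyl and 2-fluoro-4-(methoxycarbonyl)phenyl are not interchangeable here. The step from compound 2 to compound 3 cannot be read, as compound 2 has no number, and the swap of trifluoromethyl for cyano therefore remains without a measured size. Nothing available bears on the reason for the rise in the number.

Still open, on these data alone, is which part of the difference between these two aryl groups carries the step: the cyano and chloro pair, or the fluoro and methoxycarbonyl pair. Also open, as far as these compounds go, is whether a carboxylic acid in place of the methoxycarbonyl group would keep the number near that of compound 1, at 800 nM, or move it.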